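A few compounds are considered here, and "the series" means these few. Any claim that something is new, unique, unknown or untested is made for them only; others in the source may bear on it.

Compound 1, `COc1ccc(NC(=O)C2CCc3ccccc3N2)cc1`, was tested in a functional assay on NUGC-3 cells (Homo sapiens) for cytotoxicity, read by sulforhodamine B assay, with a stated time of 72 h (a higher number here means a weaker inhibitor of growth, a lower number a stronger inhibitor of growth), where compound 1 gives 51900 nM. Among the measured compounds shown here, only one other compound has been measured alongside it: compound 2, `O=C(Nc1ccccc1O)C1CCc2ccccc2N1C(=O)c1ccccc1`, which in this assay gives 3780 nM. For the measured compounds named here, of these two numbers, the one for compound 1 is the higher, and the gap between the two values lies beyond the scatter of repeated measurements, so compound 1 is the weaker inhibitor of growth of the pair.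

The next compound, compound 3, `O=C(Nc1ccc(O)cc1)C1CCc2ccccc2N1`, has not yet been measured in this assay. It differs from compound 1 in one place: hydrogen in place of methyl on an oxygen on an aromatic ring. Going by the values given here, no pair of measured compounds differing in exactly this way is available, so the size of the step cannot be read off from the data, and compound 2, carrying a different acyl group and a differently placed hydroxy, gives no direct guide.

From what is known, the step from compound 1 to compound 3 is expected to be small, a 1.5-fold lower number from compound 1 to compound 3 (0.17 log units; within the scatter), with a slight move toward stronger inhibition at most. Compound 3 is therefore estimated at 35000 nM, within a range from 10000 nM to 120000 nM.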

Compound 3, concentration for 50% growth inhibition: > 100000 nM
Compound 3 gave a limit, no number (the forecaster's own chance of this, stated with the estimate: 15%); middle value at least 2.8-fold (0.45 log units) from the limit.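

In this assay compound 3 gives > 100000 nM, which is a limit of the assay and not a number. On this oxygen on an aromatic ring, the change from methoxy to hydroxy gives an at least 1.9-fold higher number from compound 1 to compound 3 (0.28 log units; that floor lies within the scatter). This is the first step that can be read for a single change in one place, and it shows that taking away the methyl brings no gain in growth inhibition here, something compound 2, which differs in more than one place, could not show; the true size of the step stays unknown, and the only thing that bears on the reading is the limit itself: the limit of > 100000 nM in this assay, at which 1 of the 3 values shown sits.

The compounds shown leave open whether the methyl is the one group that serves at this place, or whether ethoxy, a longer chain on the same oxygen, or an amine in place of the methoxy would give a lower number in this assay. They also leave open whether the same change from methoxy to hydroxy would have a similar outcome on a compound carrying the benzoyl group of compound 2.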